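Fluoro substitution on the chlorobenzimidazolone core: tolerability notes

This account rests on a few compounds, and the source may have more. Where it says the series, first, only, none or still open, it means among the compounds named here.

The series rests on a shared chlorinated bicyclic core carrying either a sulfonyl or a benzyl group. Compound 1 `Cc1cc(C)cc(S(=O)(=O)n2c(=O)[nH]c3ccc(Cl)cc32)c1` gives 39000 nM in an ADME assay on MT4 cells (Homo sapiens) for cytotoxicity; a higher number here means that more compound is tolerated, a lower number that less compound is tolerated. Compound 3 `Cc1cc(C)cc(S(=O)(=O)n2c(=O)[nH]c3cc(F)c(Cl)cc32)c1` is the fluorinated analogue of compound 1; in this assay compound 3 gives 140000 nM. The change between them, (fluoro in place of hydrogen on an aromatic carbon), produced a 3.6-fold higher number from compound 1 to compound 3 (0.56 log units; beyond the scatter).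

Compound 2 `O=c1[nH]c2ccc(Cl)cc2n1Cc1cc(F)cc(F)c1` carries the benzyl group instead of the sulfonyl; the difference between the two cores is not broken down here. In this assay compound 2 reaches only a limit, > 424000 nM, and no number within range. This is the limit of > 424000 nM in this assay, at which 1 of the 3 values shown sits.

Compound 4 `O=c1[nH]c2cc(F)c(Cl)cc2n1Cc1cc(F)cc(F)c1` is the fluorinated counterpart of compound 2, not yet measured. The change from compound 2 to compound 4, (fluoro in place of hydrogen on an aromatic carbon), is the same change as that from compound 1 to compound 3, placed identically on the core.

For compound 4 in this assay the step is expected to resemble a 3.6-fold higher number from compound 1 to compound 3 (0.56 log units; beyond the scatter) in direction, that is a higher number, because the same change in compound 1 gave a 3.6-fold higher number from compound 1 to compound 3 (0.56 log units; beyond the scatter). Since compound 2 already sits at the limit > 424000 nM, compound 4 is expected to sit at or beyond the same limit, with only a limit likely reported. The estimated step from compound 2 to compound 4 is a step that the limit leaves unreadable from compound 2 to compound 4. Compound 4 is therefore estimated at 600000 nM, within 300000 nM to 1500000 nM.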

Compound 4, half-maximal cytotoxic concentration: > 400000 nM
Compound 4: only a limit was reported; the forecaster's own chance of this, stated with the estimate: 80%; the middle value does not contradict the limit.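

Compound 2 stands only at a limit in this assay, > 424000 nM. Compound 4 also stands only at a limit, > 400000 nM, and no step can be read between it and compound 2. The compounds shown leave open whether fluoro in place of hydrogen on an aromatic carbon shifts the number for the benzyl compounds at all, and by how much.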